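The compounds below may be only part of what the source reports. "The series", "measured", "known", "first", "only" and "open" are said of these compounds alone.

Measured so far in an assay for inhibition of inositol hexakisphosphate kinase 2 (Homo sapiens), read by colorimetric assay, coupled enzyme assay and malachite green, with a stated time of 120 min, in the presence of a further agent that is not named here; a lower number here means a stronger inhibitor, a higher number a weaker inhibitor:
compound 1, `O=C(O)c1ccc2noc(-c3ccc(-c4cccnc4)cc3)c2c1`, gives 54 nM
compound 2, `O=C(O)c1ccc2noc(-c3ccc(-c4ccncc4)cc3)c2c1`, gives 150 nM
compound 3, `O=C(O)c1ccc2noc(-c3ccc(Oc4ccccn4)cc3)c2c1`, gives 1190 nM

Compound 1 stands lowest of the three numbers in this assay; compound 2 is nearest to it, compound 3 furthest. The step of a 2.8-fold higher number from compound 1 to compound 2 (0.44 log units; beyond the scatter) is modest, the step of a 22-fold higher number from compound 1 to compound 3 (1.34 log units; beyond the scatter) large, and a 7.9-fold higher number from compound 2 to compound 3 (0.90 log units; beyond the scatter) lies between them.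

Compound 4, `O=C(O)c1ccc2noc(-c3ccc(NC(=O)C4CCCC4)cc3)c2c1`, is not yet measured. It differs from compound 1 in one place: (cyclopentylcarbonyl)amino in place of pyridin-3-yl on an aromatic carbon.

Among the compounds with values here, none of the measured steps makes this change directly. The nearest guide is the step from compound 1 to compound 3, a 22-fold higher number from compound 1 to compound 3 (1.34 log units; beyond the scatter), where the pyridin-3-yl was likewise given up and a group joined through a linker entered at the same place; that step was large. The step of a 2.8-fold higher number from compound 1 to compound 2 (0.44 log units; beyond the scatter), which keeps an aromatic ring, was modest. A loss beyond the scatter is therefore expected for compound 4, smaller than the step to compound 3 but clearly beyond the step to compound 2. The step expected for compound 4 is a 5.6-fold higher number from compound 1 to compound 4 (0.74 log units; beyond the scatter). The value of compound 4 in this assay is estimated at 300 nM, with a range from 80 nM to 1200 nM.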

Compound 4, half-maximal inhibitory concentration: 190 nM
Estimate against measurement, compound 4: 1.6-fold (0.20 log units) above; measured number inside the range.
By their numbers in this assay, from the lowest: compound 1; then compounds 2 and 4 (each within the scatter of the next); then compound 3.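

In this assay, this place on the aromatic carbon accepts a group with no aromatic ring: (cyclopentylcarbonyl)amino in place of pyridin-3-yl gives a 3.5-fold higher number from compound 1 to compound 4 (0.55 log units; beyond the scatter), and in place of pyridin-4-yl it gives a 1.3-fold higher number from compound 2 to compound 4 (0.10 log units; within the scatter), so compound 2 and compound 4 cannot be told apart here. Against (pyridin-2-yl)oxy, the change gives a 6.3-fold lower number from compound 3 to compound 4 (0.80 log units; beyond the scatter), so a ring joined through a linker does not by itself account for the high number of compound 3, since compound 4 also carries its ring on a linker. No supporting data bear on why these groups differ.

Going by these compounds, it remains open which part of the (cyclopentylcarbonyl)amino group matters: the amide hydrogen, the carbonyl or the cyclopentyl ring. Also open, on these data alone, is how a plain amine, a longer chain or a carboxylic acid at this place would compare with pyridin-3-yl.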